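The source may report more compounds than this note shows. Statements on the series, on what has been measured and on what is new or still open speak of the compounds shown alone.

Of the compounds shown here, two have been measured so far in a physicochemical assay for lipophilicity; a higher number here means a more lipophilic compound, a lower number a more polar compound. Compound 1, `C/C=C/COC(=O)/C=C(C)/C=C/CC(C)CCCC(C)(C)OC`, gives 6.07 in this assay. Compound 2, `CCOC(=O)/C=C(C)/C=C/CC(C)CCCC(C)(C)OC(C)=O`, gives 5.57 in this assay, which is the lower of the two numbers, with compound 1 standing higher by a gap beyond the usual scatter of repeated measurements. Going by the values given here, the two compounds differ in more than one place, so no single step between them is separated out here.

The next compound, compound 3, `C=C(C)CCCC(C)C/C=C/C(C)=C/C(=O)OCC`, has not yet been measured. Its change from compound 2 is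
1-methylethenyl in place of 1-acetoxy-1-methylethyl on a saturated chain carbon, five bonds along the chain from a double-bonded chain carbon
The group that leaves carries two hydrogen-bond acceptors, while the 1-methylethenyl group that enters carries none, so a rise in this assay beyond the scatter is expected. On that basis compound 3 is estimated at 6.5, within a range from 5.9 to 7.1. That estimate means an expected step of a number 0.93 log units higher from compound 2 to compound 3 (beyond the scatter) in this assay.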

Compound 3, partition coefficient: 6.19
Estimate against measurement, compound 3: 0.31 log units above, within the range that was stated.
By their numbers in this assay, from the lowest: compound 2; then compounds 1 and 3 (each within the scatter of the next).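

Putting 1-methylethenyl in place of 1-acetoxy-1-methylethyl on a saturated chain carbon, five bonds along the chain from a double-bonded chain carbon, gives a number 0.62 log units higher from compound 2 to compound 3 (beyond the scatter) in this assay. Going by these compounds alone, this is the first comparison here that isolates one place, showing that the read-out responds to a change at this position, which the earlier pair, differing in more than one place, could not show. No measurement here shows which feature of this exchange accounts for the step.

The compounds shown leave open where a 1-hydroxy-1-methylethyl group or a plain 1-methylethyl group at this place would fall relative to compound 2 and compound 3. They also leave open whether the same exchange would give a step of similar size with the ester of compound 1.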